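Swapping Pyridin-4-yl for Benzyl in Compound 1

The source may report more compounds than this note shows. Statements on the series, on what has been measured and on what is new or still open speak of the compounds shown alone.

In a functional assay on KG-1 cells (Homo sapiens) for cytotoxicity, read by luminescence and CellTiter-Glo, with a stated time of 3 days (a lower number here means a stronger inhibitor, a higher number a weaker inhibitor), compound 1 `N#Cc1ccc(NC(=O)c2cc(-c3ccncc3)ccc2O)cc1` gives 7990 nM, the higher of the two numbers available. Compound 2 `Cc1ccc(C(=O)Nc2ccc(C#N)cc2)c(O)c1` gives 2560 nM, and the gap between these two lies beyond the usual scatter of repeated measurements, making compound 1 the weaker inhibitor of the pair. Compound 3 `N#Cc1ccc(NC(=O)c2cc(Br)c3cccnc3c2O)cc1` adds no number, since its result is "not determined" (no result reported).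

Compound 4 `N#Cc1ccc(NC(=O)c2cc(Cc3ccccc3)ccc2O)cc1` has not yet been measured. It carries benzyl in place of pyridin-4-yl on an aromatic carbon, para to a hydroxy group: benzyl in place of pyridin-4-yl on an aromatic carbon.

Within the data shown here, no measured pair shows a change of this kind, so any expectation here is loose. Among the measured compounds shown here, the one hint is that compound 2, which also lacks pyridin-4-yl, gives 2560 nM. A moderate move towards a lower number in this assay therefore seems more likely than a large one. The estimated change is a 2.3-fold lower number from compound 1 to compound 4 (0.36 log units; beyond the scatter). For compound 4, the expected value is 3500 nM, within an estimated range of 1000 nM to 10000 nM.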

Compound 4, half-maximal inhibitory concentration: 1930 nM
The estimate for compound 4 lay 1.8-fold (0.26 log units) above the measured number; the range from low to high includes it.
By their numbers in this assay, from the lowest: compounds 4 and 2 (each within the scatter of the next); then compound 1.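

Replacing pyridin-4-yl with benzyl on this aromatic carbon, para to a hydroxy group, gives in this assay a 4.1-fold lower number from compound 1 to compound 4 (0.62 log units; beyond the scatter), so the number responds to the group placed here. Pyridin-4-yl carries a ring nitrogen counted as a hydrogen-bond acceptor, while benzyl has a carbon-only ring and no such acceptor, but this single step changes several features at once and cannot separate them. Nothing available explains why the number falls.

Still open, from the compounds shown here alone, is which feature matters: phenyl at this carbon would keep the carbon-only ring while removing the benzyl linking carbon, and 3-pyridylmethyl would restore a ring nitrogen while keeping that link. It is also unknown how a longer chain, such as 2-phenylethyl, or a carboxylic acid would behave at this position.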